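Naphthalen-1-yl replaces 2-methoxyphenyl in a cell assay

The source may report more compounds than this note shows. Statements on the series, on what has been measured and on what is new or still open speak of the compounds shown alone.

Values measured in an ADME assay on Vero cells (Chlorocebus sabaeus) for inhibition, read by MTT assay, with a stated time of 72 h; a lower number here means a stronger inhibitor, a higher number a weaker inhibitor:
Compound 1 `COc1ccccc1OS(=O)(=O)C1CC2OC1C(c1ccc(NC(=O)CCCCCCC(=O)NO)cc1)=C2c1ccc(O)cc1` gives > 100000 nM as a limit
Compound 2 `Cc1ccccc1OS(=O)(=O)C1CC2OC1C(c1ccc(NC(=O)CCCCCCC(=O)O)cc1)=C2c1ccc(O)cc1` gives > 100000 nM as a limit
Compound 3 `Cc1ccc(OS(=O)(=O)C2CC3OC2C(c2ccc(NC(=O)CCCCCCC(=O)O)cc2)=C3c2ccc(O)cc2)cc1` gives > 100000 nM as a limit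

Compound 1 has no exact number, only a limit of the assay. The other two measured compounds stand in the same position, and the whole set shares one reading: the limit of > 100000 nM in this assay, at which 3 of the 3 values shown sit. No order among the three can therefore be told.

Compound 4 `O=C(CCCCCCC(=O)Nc1ccc(C2=C(c3ccc(O)cc3)C3CC(S(=O)(=O)Oc4cccc5ccccc45)C2O3)cc1)NO` differs from compound 1 in one place: naphthalen-1-yl in place of 2-methoxyphenyl on an oxygen. In plain words, naphthalen-1-yl stands in place of 2-methoxyphenyl on an oxygen, and that oxygen's other neighbour is the sulfonyl sulfur.

One measured step changes the group on this oxygen: a step that the two limits leave unreadable from compound 2 to compound 3, with 4-methylphenyl in place of 2-methylphenyl. Both of its ends are limits, so it gives no size to carry over to the new change. With nothing readable pointing either way, no step beyond the scatter is expected in this assay, and a further limit is the most likely report for compound 4. The estimated change, a number no higher from compound 1 to compound 4 (the limit leaves the size open), has no expected direction. Compound 4 is expected at about 100000 nM, with an estimated range of 30000 nM to 200000 nM as its span.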

Compound 4, half-maximal inhibitory concentration: > 100000 nM
Compound 4: no number, only a limit; the forecaster's own chance of this, stated with the estimate: 75%; the middle value lies on the limit itself.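

In this assay compound 4 gives > 100000 nM, which is a limit of the assay and not a number. Compound 1 also has only a limit, so no step can be read between compound 1 and compound 4, and the whole set shares one reading: the limit of > 100000 nM in this assay, at which 4 of the 4 values shown sit.

The compounds shown leave open whether the group on this oxygen changes the result in this assay at all, as none of them gives an exact number.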